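Trifluoromethyl in place of 4-chlorophenyl on a weak inhibitor

The source may hold more compounds than are shown below. What is called first, only, known or untested is meant among the compounds shown, and "the series" means these compounds.

In a functional assay on PC-3 cells (Homo sapiens) for inhibition, read by sulforhodamine B assay, with a stated time of 48 h, tested at 10 uM (a lower number here means less inhibition of growth, a higher number more inhibition of growth at the concentration tested), compound 1 (`CC(=O)c1ccc(NC(=O)Cn2nc(-c3ccc(Cl)cc3)nc2N)cc1`) gives 20.3% and compound 2 (`C/C(=N\O)c1ccc(NC(=O)Cn2nc(-c3ccc(Cl)cc3)nc2N)cc1`) gives 28.9% which lies within the scatter of it. Compound 3 (`COc1cc(-c2nc3sc(-c4ccccc4)cn3n2)cc(OC)c1OC`) has a different core and gives 53% beyond the scatter of compound 1. Compound 4 (`CC(=O)c1ccc(NC(=O)Cn2nc(C(F)(F)F)nc2N)cc1`) differs from compound 1 by trifluoromethyl in place of 4-chlorophenyl on an aromatic carbon at this place. Among the compounds with values here, the one measured step, a number 8.6 percentage points higher from compound 1 to compound 2 (within the scatter), changes another place, so no measured step speaks directly to this swap. With compound 1 at 20.3% there is limited room for a fall, so no step beyond the scatter is expected in this assay here. The estimated change is a number 6.3 percentage points lower from compound 1 to compound 4 (within the scatter) as a rough expectation. For compound 4 the expected value is 14% with an estimated range from 2% to 30% as its likely span.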

Compound 4, percent growth inhibition at one concentration: 10.6%
Estimate against measurement, compound 4: 3.4 percentage points above; measured number inside the range.
By their numbers in this assay, from the lowest: compounds 4, 1 and 2 (each within the scatter of the next, the first and the last beyond it); then compound 3.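

In this assay, the change at this position reads a number 9.7 percentage points lower from compound 1 to compound 4 (within the scatter). The six-membered aromatic ring of 4-chlorophenyl is therefore not required to keep compound 4 within the scatter of compound 1, although both numbers are low and neither compound shows much inhibition of growth at the concentration tested. No measurement shown offers an explanation for this result. As far as these compounds go, whether an amine or a carboxylic acid on this aromatic carbon would lift the number beyond the scatter remains open. So does whether trifluoromethyl would give a similar result on compound 2.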